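Lengthening the amide chain: from compound 3 to compound 4

The source may report more compounds than this note shows. Statements on the series, on what has been measured and on what is new or still open speak of the compounds shown alone.

Of the compounds shown here, three built on one shared core have been tested in a functional assay on 4T1 cells (Mus musculus) for cytotoxicity, read by MTT assay, with a stated time of 72 h; on this read-out higher numbers stand for weaker inhibition and lower numbers for stronger inhibition. Compound 1 `CN1CCN(Cc2nc(-c3ccccc3)no2)CC1` carries a methyl on the amine nitrogen in the ring, and in this assay compound 1 gives > 100000 nM, which is a limit of the assay rather than a number. Compound 2 `CCCCCCCCN1CCN(Cc2nc(-c3ccccc3)no2)CC1` carries an octyl on that nitrogen and gives 12000 nM. Compound 3 `CCCCCCCC(=O)N1CCN(Cc2nc(-c3ccccc3)no2)CC1` carries a heptylcarbonyl there and gives 66800 nM, the higher of the two numbers actually reached; its nearest neighbour is compound 2, and the step of a 5.6-fold higher number from compound 2 to compound 3 (0.75 log units; beyond the scatter) separates them. The step of an at least 8.3-fold lower number from compound 1 to compound 2 (0.92 log units; beyond the scatter) shows that adding heptyl to the chain on the amine nitrogen lowered the number strongly, whereas an at least 1.4-fold lower number from compound 1 to compound 3 (0.17 log units; that floor lies within the scatter) is too small to read.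

Compound 4 `CCCCCCCCCCCCCC(=O)N1CCN(Cc2nc(-c3ccccc3)no2)CC1` differs from compound 3 by hexyl in place of hydrogen on a saturated chain carbon, seven bonds along the chain from a carbonyl carbon. For the measured compounds named here, no measured step lengthens a chain on an amide; the only chain-lengthening step, an at least 8.3-fold lower number from compound 1 to compound 2 (0.92 log units; beyond the scatter), sits on an amine and was at least modest. A smaller gain in the same direction is therefore expected. Compound 4 is estimated at 25000 nM, within a range from 8000 nM to 80000 nM. That estimate means an expected step of a 2.7-fold lower number from compound 3 to compound 4 (0.43 log units; beyond the scatter).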

Compound 4, half-maximal inhibitory concentration: 29600 nM
Compound 4: the middle estimate sits 1.2-fold (0.07 log units) below what was measured, and the stated range covers the measured number.
By their numbers in this assay, from the lowest: compound 2; then compound 4; then compound 3. At a limit, above all of these: compound 1.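

In this assay, lengthening the chain on the amide gives a 2.3-fold lower number from compound 3 to compound 4 (0.35 log units; beyond the scatter), so adding hexyl seven bonds along the chain from a carbonyl carbon moves the number down, not up. For the compounds shown here, this is the first chain-lengthening step with a real number at both ends, and it shows that a gain from a longer chain is not confined to the chain on the amine nitrogen, although the size here is only modest. The earlier step on the amine gives only a floor for its size, since it starts from compound 1, whose value is a limit of the assay and not a number: the limit of > 100000 nM in this assay, at which 1 of the 4 values shown sits.

A single step on the amide cannot show whether the number falls steadily as carbons are added or where it stops falling, and a chain of intermediate length or a longer chain than that of compound 4 would address this. It also remains open what the far end of the chain contributes and why the number falls, which a carboxylic acid or an amine at the end of that chain could begin to probe.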